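Series notes: carboxy to carbamoyl on the side chain

The compounds below may be only part of what the source reports. "The series", "measured", "known", "first", "only" and "open" are said of these compounds alone.

Measured in a functional assay on HCT-116 cells (Homo sapiens) for antiproliferative activity, read by sulforhodamine B assay, with a stated time of 72 h; on this read-out higher numbers stand for weaker inhibition and lower numbers for stronger inhibition:
compound 1, `Cn1ncc(Cl)c1-c1cc(C(=O)N[C@@H]2CNCC[C@H]2c2ccc(C(F)(F)F)cc2)oc1Cl`, 280 nM
compound 2, `Cn1ncc(Cl)c1-c1cc(C(=O)N[C@@H]2CN[C@H](CCO)C[C@H]2c2ccc(F)c(F)c2)oc1Cl`, 360 nM
compound 3, `Cn1ncc(Cl)c1-c1cc(C(=O)N[C@@H]2CN[C@H](CC(=O)O)C[C@H]2c2ccc(Cl)c(Cl)c2)oc1Cl`, 4020 nM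

Compound 3 stands at the highest number of the three, beyond the scatter from compound 2 and from compound 1 alike, so it is the weakest inhibitor of the set in this assay. Compound 4, `Cn1ncc(Cl)c1-c1cc(C(=O)N[C@@H]2CN[C@H](CC(N)=O)C[C@H]2c2ccc(Cl)c(Cl)c2)oc1Cl`, is not yet measured. It differs from compound 3 by amino in place of hydroxy on a carbonyl carbon. Among the measured compounds shown here, no step between measured compounds covers this exchange, so the expectation rests on where compound 3 stands relative to compound 2 and compound 1, neither of which carries the carboxy group of compound 3. In this assay the step of a 4.5-fold lower number from compound 3 to compound 4 (0.65 log units; beyond the scatter) is expected to lower the number beyond the scatter. Compound 4 is estimated at 900 nM, within 300 nM to 2700 nM.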

Compound 4, half-maximal inhibitory concentration: 650 nM
Beside the measured number, compound 4's estimate is 1.4-fold (0.14 log units) above it, and the stated range covers the measured number.
By their numbers in this assay, from the lowest: compounds 1, 2 and 4 (each within the scatter of the next, the first and the last beyond it); then compound 3.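

In this assay, among the compounds shown here, amino in place of hydroxy on a carbonyl carbon gives a 6.2-fold lower number from compound 3 to compound 4 (0.79 log units; beyond the scatter), the first exchange that can be read in one place. The side chain therefore responds to this exchange at the carbonyl carbon, with the rest of the molecule held constant. No measurement on hand accounts for the step.

Open, going by these compounds, is how a methyl ester or a methyl amide on the same chain would read against compound 3 and compound 4. Also open, on these data alone, is whether a longer chain carrying the carbamoyl group would move the number.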